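Demethylation of the aryl methoxy group in a pyrazole series

The source may hold more compounds than are shown below. What is called first, only, known or untested is meant among the compounds shown, and "the series" means these compounds.

Measured so far:
- compound 1, `COc1cc(C)cc(-c2c(-c3ccnc(-c4ccc(C(C)=O)cc4)c3)cnn2CC#N)c1`: -37%
- compound 2, `COc1cc(C)cc(-c2nn(CC#N)cc2-c2ccc(-c3cccc(C(C)=O)c3)nc2)c1`: -13%
- compound 3, `COc1cc(C)cc(-c2nn(CC#N)cc2-c2ccnc(-c3ccc(N(C)C)cc3)c2)c1`: -40%

In a functional assay on SK-MEL-5 cells (Homo sapiens) for cytotoxicity, read by sulforhodamine B assay, with a stated time of 48 h, tested at 1 uM (a lower number here means a stronger effect, a higher number a weaker effect of the compound at the concentration tested), compound 3 gives -40%, the lowest number among the three measured compounds. Compound 1 gives -37%, which lies within the scatter of compound 3, so the two cannot be ranked against each other. Compound 2 gives -13%, a gap beyond the scatter, so compound 3 shows the stronger effect of those two.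

The next compound is compound 4, `Cc1cc(O)cc(-c2nn(CC#N)cc2-c2ccnc(-c3ccc(N(C)C)cc3)c2)c1`. It differs from compound 3 by hydrogen in place of methyl on an oxygen on an aromatic ring

Going by the values given here, no pair of measured compounds shares this kind of change, so there is no measured step to lean on. A change that removes a single carbon at the oxygen and leaves everything else in place is expected to move the number little; the estimate is for no step beyond the scatter, in either direction, with a number 5 percentage points higher from compound 3 to compound 4 (within the scatter) as the expected step. Compound 4 is therefore estimated at -35% in this assay, with a range from -55% to -10%.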

Compound 4, a percentage reported as activity, at one concentration (the size of the read-out at that concentration, not a potency): -26%
Compound 4: the middle estimate sits 9 percentage points below what was measured; the range from low to high includes it.
By their numbers in this assay, from the lowest: compounds 3 and 1 (each within the scatter of the next); then compound 4; then compound 2.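

Going by these compounds alone, the aryl methoxy position gives the first single-change step, and the change is not silent: in this assay, methoxy to hydroxy gives a number 14 percentage points higher from compound 3 to compound 4 (beyond the scatter), a modest weakening of the effect at the concentration tested. The methyl on this oxygen therefore counts in the 3-methoxy-5-methylphenyl group, although this reading rests on one pair alone. Nothing measured here gives a reason for the step.

The compounds shown leave open whether the same change would give a similar step with the different groups carried by compound 1 and compound 2. They also leave open how a longer ether such as ethoxy, or an amine in place of the hydroxy, would read in this assay.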